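The source may hold more compounds than are shown below. What is called first, only, known or untested is meant among the compounds shown, and "the series" means these compounds.

The measured compounds, all tested in a functional assay on PC-3 cells (Homo sapiens) for cytotoxicity, read by MTT assay, with a stated time of 72 h; a lower number here means a stronger inhibitor, a higher number a weaker inhibitor:

Compound 1 `CC1=C(/C=C/C(=O)/C=C/c2cccc(C(F)(F)F)c2)C(C)(C)CCC1` gives 7700 nM.
Compound 2 `CC1=C(/C=C/C(=O)/C=C/c2ccc(C(F)(F)F)cc2)C(C)(C)CCC1` gives 12000 nM.
Compound 3 `CC1=C(/C=C/C(=O)/C=C/c2cccc(C)c2)C(C)(C)CCC1` gives 35000 nM.

Compound 2 holds the second highest of these three numbers. Its nearest neighbour is compound 1, whose value is lower but within the scatter, so the two cannot be ordered; compound 3 lies beyond the scatter, with the higher number of the pair.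

Compound 4 `CC1=C(/C=C/C(=O)/C=C/c2ccc(-c3ccccc3)cc2)C(C)(C)CCC1` differs from compound 2 in one place: phenyl in place of trifluoromethyl on an aromatic carbon. Within the data shown here, the only measured step that bears on this is a 4.5-fold higher number from compound 1 to compound 3 (0.66 log units; beyond the scatter), where another group replaced the trifluoromethyl on the same aromatic ring and the number rose modestly. That step concerns methyl, not phenyl, and a different place on the ring, so it is only a loose guide. On that basis a modest weakening in this assay is expected for compound 4, with a step of about a 1.3-fold higher number from compound 2 to compound 4 (0.12 log units; within the scatter), though a change within the scatter would not surprise. The expected value for compound 4 is 16000 nM, with a range from 5000 nM to 45000 nM.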

Compound 4, half-maximal inhibitory concentration: 47800 nM
Beside the measured number, compound 4's estimate is 3.0-fold (0.48 log units) below it; measured number above the stated range.
By their numbers in this assay, from the lowest: compounds 1 and 2 (each within the scatter of the next); then compounds 3 and 4 (each within the scatter of the next).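

In this assay, phenyl in place of trifluoromethyl on this aromatic carbon, para to a large group, gives a 4.0-fold higher number from compound 2 to compound 4 (0.60 log units; beyond the scatter), so the change weakens the compound by more than the scatter. Until now, the only measured replacement of trifluoromethyl was methyl at a different place on the ring, which gave a 4.5-fold higher number from compound 1 to compound 3 (0.66 log units; beyond the scatter); both replacements shown therefore raise the number, and this result extends that direction to a group bringing an aromatic ring of its own. No measurement shown here bears on why the number rises with phenyl.

On these data alone, it remains open whether methyl at this same place would also raise the number. As far as these compounds go, it is also open whether a methoxy group, an amine or a carboxylic acid here would keep the number of compound 2 12000 nM or lose ground as phenyl does.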